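This account rests on a few compounds, and the source may have more. Where it says the series, first, only, none or still open, it means among the compounds named here.

Going by the values given here, in a functional assay on FM3A cells (Mus musculus) for antiproliferative activity (a higher number here means a weaker inhibitor, a lower number a stronger inhibitor), compound 2 (`COc1cc(C(=O)c2sc(-c3ccsc3)cc2N)cc(OC)c1OC`) gives 3.7 nM, the lower of the two numbers measured so far, while compound 1 (`COc1cc(C(=O)c2sc(-c3cccc([N+](=O)[O-])c3)cc2N)cc(OC)c1OC`) gives 17 nM. Compound 3 (`COc1cc(C(=O)c2sc(-c3ccc(C)cc3)cc2N)cc(OC)c1OC`) carries 4-methylphenyl in place of thiophen-3-yl on an aromatic carbon. Among the compounds with values here, the one measured step at this place, a 4.6-fold lower number from compound 1 to compound 2 (0.66 log units; beyond the scatter), exchanged 3-nitrophenyl for thiophen-3-yl and was modest. A substituted phenyl now returns, so the expected change in this assay is a modest rise, a 2.4-fold higher number from compound 2 to compound 3 (0.39 log units; beyond the scatter). For compound 3 the estimated value is 9 nM, with an expected range of 3.5 nM to 25 nM.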

Compound 3, half-maximal inhibitory concentration: 16 nM
Estimate against measurement, compound 3: 1.8-fold (0.25 log units) below; measured number inside the range.
By their numbers in this assay, from the lowest: compound 2; then compounds 3 and 1 (each within the scatter of the next).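

In this assay, the thiophen-3-yl group of compound 2 now stands apart from two different substituted phenyl groups: 4-methylphenyl in its place gives a 4.3-fold higher number from compound 2 to compound 3 (0.64 log units; beyond the scatter). The two phenyl groups themselves are not separated, with a 1.1-fold lower number from compound 1 to compound 3 (0.03 log units; within the scatter), so replacing 3-nitrophenyl with 4-methylphenyl has no readable effect here. Nothing at hand explains either step. On these data alone, whether a furyl group would hold the low number of compound 2 remains open, as does the outcome for a phenyl carrying an amine or a carboxylic acid.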